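Methylsulfanyl on the benzyl group of compound 2

A few compounds are considered here, and "the series" means these few. Any claim that something is new, unique, unknown or untested is made for them only; others in the source may bear on it.

Measured so far:
Compound 1, `CSc1ccc(Cc2nn(C(C)(C)C)c(=O)c3ccccc23)cc1`: > 100000 nM
Compound 2, `Cn1nc(Cc2ccccc2)c2ccccc2c1=O`: <= 10000 nM

Both compounds share one core and differ in the group on the ring nitrogen and in the benzyl group. In a functional assay on aorta with Alpha-1D adrenergic receptor (Rattus norvegicus) as the target (a lower number here means that less compound is needed, a higher number that more compound is needed for the effect), compound 1 gives > 100000 nM, which is a limit of the assay and not a number. In this assay compound 2 gives <= 10000 nM, again a limit of the assay and not a number. So compound 2 stands on a limit that marks it as active at the tested level (the limit of <= 10000 nM in this assay, at which 1 of the 2 values shown sits), while compound 1 sits at the limit where no effect was seen (the limit of > 100000 nM in this assay, at which 1 of the 2 values shown sits); no step between them has been worked out, and the two changes between them cannot be separated.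

Compound 3, `CSc1ccc(Cc2nn(C)c(=O)c3ccccc23)cc1`, keeps the methyl on the nitrogen of compound 2 and carries the change (methylsulfanyl in place of hydrogen on an aromatic carbon). With compound 2 known only as a limit, the size of this step is uncertain; a modest loss of potency or none beyond the scatter seems most likely, but a larger loss cannot be ruled out. Compound 3 is expected to give 15000 nM, with a range from 3000 nM to 80000 nM. The step this estimate means is an at least 1.5-fold higher number from compound 2 to compound 3 (0.17 log units; that floor lies within the scatter), an expected small move toward weaker activity.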

Compound 3, half-maximal effective concentration: 930 nM
The estimate for compound 3 lay 16-fold (1.21 log units) above the measured number, outside the stated range (below it).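

In this assay compound 3 gives a true number, 930 nM, so a methylsulfanyl group on this aromatic carbon, para to a large group, does not by itself remove the effect. With that methylsulfanyl group held constant, methyl in place of tert-butyl on the aromatic nitrogen gives an at least 100-fold lower number from compound 1 to compound 3 (2.03 log units; beyond the scatter), which separates the two changes that could not be told apart before and ties the lack of effect in compound 1 to its tert-butyl group within this pair. The step from compound 2 to compound 3 cannot be read, because compound 2 is known only as a limit of the assay: the limit of <= 10000 nM in this assay, at which 1 of the 3 values shown sits.

On these data alone, whether methylsulfanyl improves, weakens or leaves the activity unchanged relative to hydrogen therefore stays open, and it would take a true number for compound 2 to settle this. Also open, as far as these compounds go, is how other groups behave, such as a methoxy group or an amine at the same place on the benzyl ring, or an ethyl or isopropyl group on the aromatic nitrogen, which would show how the activity changes on going from methyl to tert-butyl.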